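Amide chain changes on a shared core

This account rests on a few compounds, and the source may have more. Where it says the series, first, only, none or still open, it means among the compounds named here.

Measured compounds:
Compound 1, `CCCC(=O)Nc1ccc(C2=NNC(=O)CC2)cc1`, in a functional assay for inhibition, with Homo sapiens as the target (a lower number here means that less compound is needed, a higher number that more compound is needed for the effect), gives 1.44 ug/mL.
Compound 2, `CCCCC(=O)Nc1ccc(C2=NNC(=O)CC2)cc1`, gives 2.64 ug/mL.
Compound 3, `O=C1CCC(c2ccc(NC(=O)CCl)cc2)=NN1`, gives 0.39 ug/mL.

Compound 3 stands lowest of the three, with a 3.7-fold lower number from compound 1 to compound 3 (0.57 log units; beyond the scatter) and a 6.8-fold lower number from compound 2 to compound 3 (0.83 log units; beyond the scatter). Compound 4, `CC(Cl)C(=O)Nc1ccc(C2=NNC(=O)CC2)cc1`, is not yet measured; it differs from compound 3 by methyl in place of hydrogen on a saturated chain carbon bound to a carbonyl carbon and a chlorine atom. The same kind of change is seen from compound 1 to compound 2, (methyl in place of hydrogen on a saturated chain carbon, three bonds along the chain from a carbonyl carbon), though there the place is a saturated chain carbon three bonds along the chain from a carbonyl carbon, whereas in compound 4 it is a saturated chain carbon bound to a carbonyl carbon and a chlorine atom. That earlier step was a 1.8-fold higher number from compound 1 to compound 2 (0.26 log units; within the scatter). The cores of compound 1 and compound 3 differ by chloro in place of ethyl on a saturated chain carbon bound to a carbonyl carbon. Because the corresponding earlier step was a 1.8-fold higher number from compound 1 to compound 2 (0.26 log units; within the scatter), the step from compound 3 to compound 4 is expected to be small, a 1.5-fold higher number from compound 3 to compound 4 (0.19 log units; within the scatter). Compound 4 is therefore estimated at 0.6 ug/mL, between 0.25 ug/mL and 1.5 ug/mL.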

Compound 4, half-maximal effective concentration: 0.45 ug/mL
The estimate for compound 4 lay 1.3-fold (0.12 log units) above the measured number; the measured number falls inside the stated range.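

In this assay, methyl in place of hydrogen gives a small step on both cores, and the two steps do not differ: the same change on two cores in this assay, a 1.8-fold higher number (0.26 log units; within the scatter) from compound 1 to compound 2 and a 1.2-fold higher number (0.06 log units; within the scatter) from compound 3 to compound 4, 1.6-fold (0.20 log units) apart, within the scatter of two such steps. The step of a 1.2-fold higher number from compound 3 to compound 4 (0.06 log units; within the scatter) stays within the scatter, while the chlorinated compound 4 keeps a clear gap to the unchlorinated chains, with a 5.9-fold lower number from compound 2 to compound 4 (0.77 log units; beyond the scatter) and a 3.2-fold lower number from compound 1 to compound 4 (0.51 log units; beyond the scatter). This supports carrying the change between these two cores only, at two different places on the chain; a single pair per core shows nothing about other cores or other assays.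

Still open, as far as these compounds go, is how bromo, hydroxyl or an amine in place of the chlorine would read in this assay. From the compounds shown here alone, a longer chain such as 1-chloropropyl also remains open.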